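The source may report more compounds than this note shows. Statements on the series, on what has been measured and on what is new or still open speak of the compounds shown alone.

Measured so far:
compound 1 `O=C(CBr)Nc1ccc(C(=O)/C=C/c2ccco2)cc1` — 30%
compound 2 `COc1ccc(/C=C/C(=O)c2ccc(NC(=O)CO[N+](=O)[O-])cc2)cc1` — 33%

In a functional assay on the whole organism (strain albino) for inhibition, with Rattus norvegicus as the target, read by paw edema, with stated times of 30 min and 1 h, at a dose of 100 mg/kg by the oral route (a higher number here means more inhibition at the dose given (going by the name of the read-out), a lower number less inhibition), compound 2 gives the highest of the two numbers, but compound 1 sits only slightly lower, within the scatter, so the two cannot be told apart on these data. Compound 3 `O=C(CO[N+](=O)[O-])Nc1ccc(C(=O)/C=C/c2ccco2)cc1` has not yet been measured. It differs from compound 2 in one place: furan-2-yl in place of 4-methoxyphenyl on a double-bonded chain carbon bound to a double-bonded chain carbon. Among the compounds with values here, no pair of measured compounds differing in a single place is available, so the size of this step is not known from a direct comparison. Compound 1, which also carries furan-2-yl and gives 30%, lies within the scatter of compound 2, and for compound 3 no step beyond the scatter is expected in this assay in either direction. Compound 3 is expected to give 31% (from 20% to 42%). The implied step, a number 2 percentage points lower from compound 2 to compound 3 (within the scatter), is expected to be small.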

Compound 3, a percentage reported as inhibition, in the whole organism at one dose (the size of the read-out at that dose, not a potency): 34%
The estimate for compound 3 lay 3 percentage points below the measured number; the range from low to high includes it.
By their numbers in this assay, from the lowest: compounds 1, 2 and 3 (each within the scatter of the next).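

In this assay, furan-2-yl in place of 4-methoxyphenyl on a double-bonded chain carbon bound to a double-bonded chain carbon gives a number 1 percentage points higher from compound 2 to compound 3 (within the scatter) and so makes no separable difference, even though a six-membered aromatic ring of carbon only gives way to a five-membered aromatic ring with 1 hetero atom. Within the data shown here, with furan-2-yl held fixed, nitrooxy in place of bromo on a saturated chain carbon bound to a carbonyl carbon gives a number 4 percentage points higher from compound 1 to compound 3 (within the scatter) and so also shows no separable step, which gives this second position its first direct comparison. Nothing available bears on the reason for either result.

As far as these compounds go, whether an amine or a carboxylic acid in place of nitrooxy, or a longer chain carrying the nitrooxy group, would move the read-out beyond the scatter remains open. The same question stands for a pyridine ring in place of furan-2-yl, and these single-dose readings give no potency for any of the compounds.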